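Swapping Nitro for Methoxy: an Expected Outcome

The compounds below may be only part of what the source reports. "The series", "measured", "known", "first", "only" and "open" are said of these compounds alone.

Compound 1 `O=C(Nc1ccccc1[N+](=O)[O-])N[C@H]1CC[C@H](Oc2ccc(F)cc2)CC1` in a functional assay on CRL2813 cells (Homo sapiens) for cytotoxicity, read by sulforhodamine B assay, with a stated time of 5 days; a higher number here means a weaker inhibitor, a lower number a stronger inhibitor: 3500 nM
Compound 2 `O=C(Nc1cccc(C(F)(F)F)c1)N[C@H]1CC[C@H](Oc2ccc(OC(F)(F)F)cc2)CC1` in this assay: 690 nM

Of the two measured compounds, compound 1 has the higher number in this assay; compound 2 sits well below it, and the gap between the two values lies beyond the scatter. Among the compounds with values here, the two compounds differ in more than one place, so no single step links them, and their values say only that compound 2 is the stronger inhibitor of the pair.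

Compound 3 `COc1ccccc1NC(=O)N[C@H]1CC[C@H](Oc2ccc(F)cc2)CC1` differs from compound 1 by methoxy in place of nitro on an aromatic carbon. Within the data shown here, nothing among the measured compounds shows the effect of this change on its own, and the only other data point, compound 2, is altered at more than one place relative to compound 1. The expectation is therefore for a step of modest size in this assay, with no firm direction, and the estimated step is a 1.4-fold lower number from compound 1 to compound 3 (0.15 log units; within the scatter). Compound 3 is expected to come out near 2500 nM, within a range of 800 nM to 8000 nM.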

Compound 3, half-maximal inhibitory concentration: > 20000 nM
Compound 3 gave a limit, no number; the forecaster's own chance of this, stated with the estimate: 5%; middle value at least 8.0-fold (0.90 log units) away from the limit.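

Within the data shown here, this is the first comparison in the set that changes a single place: going from 2-nitrophenyl to 2-methoxyphenyl, with the rest of the core held fixed, gives an at least 5.7-fold higher number from compound 1 to compound 3 (0.75 log units; beyond the scatter) in this assay. The position, ortho to a large group, is therefore not indifferent to what it carries, since on this core the nitro compound gives a readable value and the methoxy compound does not. The entry for compound 3 is a limit and not a number, which makes the step a minimum whose full size remains unread: the limit of > 20000 nM in this assay, at which 1 of the 3 values shown sits.

The comparison rests on one pair on one core, and no measured property of either group is given, so it cannot say why the swap matters or whether it would carry over to the core of compound 2. From the compounds shown here alone, whether an amine, a nitrile or a plain hydrogen at this position would behave like the nitro of compound 1 or like the methoxy of compound 3 also remains open.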